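The compounds below may be only part of what the source reports. "The series", "measured", "known", "first", "only" and "open" are said of these compounds alone.

Of the compounds shown here, two have been measured in an assay on HEK293 cells for agonist activity at transient receptor potential cation channel subfamily M member 8 (Homo sapiens), read by fluorescence and calcium flux, with a stated time of 15 min; on this read-out lower numbers stand for an effect already at smaller amounts and higher numbers for an effect only at larger amounts of compound. Compound 1, `COc1ccc(OCC(=O)N(Cc2cccs2)c2ccn[nH]2)cc1`, gives 3.7 nM. Compound 2, `Cc1ccc(OCC(=O)N(C)Cc2cccs2)cc1`, gives 400 nM; this is the highest of the two numbers shown, and compound 1 stands a long way below it, a distance well beyond the usual scatter of such measurements. Compound 3, `Cc1ccc(OCC(=O)N(Cc2cccs2)c2ccn[nH]2)cc1`, has not yet been measured. It comes out of compound 2 by one change, (1H-pyrazol-5-yl in place of methyl on an amide-type nitrogen). The entering group is also found in compound 1, the compound with the much lower number, so a sizeable step downward is expected here. The step from compound 2 to compound 3 is estimated at a 50-fold lower number from compound 2 to compound 3 (1.70 log units; beyond the scatter), a move clearly beyond the scatter, because compound 1 carrying that same group gives 3.7 nM. Compound 3 is therefore expected to come out near 8 nM, with a range from 2 nM to 40 nM.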

Compound 3, half-maximal effective concentration: 0.2 nM
Estimate against measurement, compound 3: 40-fold (1.60 log units) above, outside the stated range (below it).
By their numbers in this assay, from the lowest: compound 3; then compound 1; then compound 2.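

Within this assay, 1H-pyrazol-5-yl in place of methyl on the amide-type nitrogen gives a 2000-fold lower number from compound 2 to compound 3 (3.30 log units; beyond the scatter), the first reading of this position with only one place changed. Methyl in place of methoxy on an aromatic carbon gives a 19-fold lower number from compound 1 to compound 3 (1.27 log units; beyond the scatter), so the group on that aromatic carbon still matters once 1H-pyrazol-5-yl is present, and the value of compound 1 did not reveal how low this series could go. Nothing available here accounts for the size of either step.

Going by these compounds, it remains open whether another ring on the amide-type nitrogen, such as phenyl or pyridyl, would give a number close to that of compound 3. The compounds shown also leave open how chloro or ethyl in place of methyl on the aromatic carbon would compare.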